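Notes on an ethyl step from compound 2

The source may hold more compounds than are shown below. What is called first, only, known or untested is meant among the compounds shown, and "the series" means these compounds.

Measured so far in a functional assay on MDA-MB-435 cells (Homo sapiens) for inhibition, read by sulforhodamine B assay, with a stated time of 48 h (a lower number here means that less compound is needed, a higher number that more compound is needed for the effect), for this series
- compound 1 `CCCN(c1ccc(OC)cc1)c1ncnc2occ(C)c12` gives 27.3 nM as its half-maximal effective concentration
- compound 2 `COc1ccc(Nc2ncnc3occ(C)c23)cc1` stands at "not determined" (no result reported) on the same read-out

Among the measured compounds shown here, compound 2 therefore has no place on the scale, so no step starting from it can be sized. Going to compound 3 `CCN(c1ccc(OC)cc1)c1ncnc2occ(C)c12` puts ethyl in place of hydrogen on a nitrogen on an aromatic ring and leaves the rest of the structure unchanged. For compound 3 the expectation rests on compound 1 at 27.3 nM in this assay as the only measured anchor. No step beyond the usual scatter is expected from that value, in either direction. The estimated value for compound 3 is 22 nM with an expected range from 8 nM to 60 nM in this series.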

Compound 3, half-maximal effective concentration: 8.1 nM
Beside the measured number, compound 3's estimate is 2.7-fold (0.43 log units) above it; the measured number falls inside the stated range.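

Replacing a methyl with hydrogen on a saturated chain carbon, two bonds along the chain from the nitrogen on an aromatic ring, gives a 3.4-fold lower number from compound 1 to compound 3 (0.53 log units; beyond the scatter) in this assay. This position therefore responds to a small change in its chain, and of the two chains shown, the ethyl of compound 3 goes with the lower number. Nothing at hand accounts for this step.

As far as these compounds go, the step from compound 2 to compound 3 cannot be read, as compound 2 has no number, so the effect of any chain on this nitrogen relative to hydrogen stays unknown. Also open, from the compounds shown here alone, is whether a methyl on this nitrogen, or a chain ending in an amine, would lower the number further or raise it again.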